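A few compounds are considered here, and "the series" means these few. Any claim that something is new, unique, unknown or untested is made for them only; others in the source may bear on it.

Compound 1 `Cc1nc(-c2cccc(CN(C)c3ccc4[nH]nc(C(=O)O)c4c3)c2)sc1C`: 99.9%
Compound 2 `CN(C)c1noc(-c2cccc(CN(C)c3ccc4[nH]nc(C(=O)O)c4c3)c2O)n1`: 99.9%
Compound 3 `CN(C)c1noc(-c2cccc(CNc3ccc4[nH]nc(C(=O)O)c4c3)c2)n1`: 99%

These three compounds were tested in an ADME assay on a cell-free system (plasma, Mus musculus) for protein binding, using equilibrium dialysis. When nearly all of a compound is bound, a small difference in the percentage can mean a large difference in the free share, so the free share is worth watching. Compound 3, at 99%, has the largest free share of the three, and its gaps to compound 1 and to compound 2 both lie beyond the scatter.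

Compound 4 `CN(C)c1noc(-c2cccc(CNc3ccc4[nH]nc(C(=O)O)c4c3)c2Cl)n1` is compound 3 with a single change: chloro in place of hydrogen on an aromatic carbon. Chloro takes the place of hydrogen on an aromatic carbon, ortho to a 3-(dimethylamino)-1,2,4-oxadiazol-5-yl group. For the measured compounds named here, no two measured compounds differ in only one place, so this change has no direct precedent here. The closest hint is compound 2, which has a hydroxy group on that same carbon and reads 99.9%, although it also differs from compound 3 elsewhere.

In this assay, the expected result is a small move towards more binding, estimated as a 2.0-fold lower unbound fraction from compound 3 to compound 4 (0.30 log units; within the scatter), close to the edge of the scatter. Compound 4 is expected to read about 99.5%, with an estimated range of 98.5% to 99.9%.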

Compound 4, plasma protein binding in the Mus musculus assay: 99.4%
Beside the measured number, compound 4's estimate is 1.2-fold (0.08 log units) (unbound fraction) below it; the range from low to high includes it.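

In the Mus musculus assay, compound 3 reads 99% and compound 4 reads 99.4%, and chloro in place of hydrogen on this aromatic carbon, ortho to a 3-(dimethylamino)-1,2,4-oxadiazol-5-yl group, gives a 1.7-fold lower unbound fraction from compound 3 to compound 4 (0.22 log units; within the scatter), which is the only direct reading of a single change among these compounds and stays within the scatter. In a physicochemical assay for solubility, measured as kinetic solubility, at pH 7.4 (a higher number here means a more soluble compound, a lower number a less soluble compound), compound 3 reads 255000 nM and compound 4 reads 296000 nM, and the same change gives a 1.2-fold higher number from compound 3 to compound 4 (0.06 log units; within the scatter), also within the scatter. This position therefore carries a chloro with no step beyond the scatter in either assay, and nothing available explains why.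

Going by these compounds, how fluoro, methyl or methoxy on this same aromatic carbon would read in the Mus musculus assay remains open, as does whether any such group would give a step beyond the scatter. On these data alone, the chloro step also rests on a single pair of compounds, so its size in other members, such as those with a methyl group on the nitrogen of the linker, remains unknown.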